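This account rests on a few compounds, and the source may have more. Where it says the series, first, only, none or still open, it means among the compounds named here.

Measured so far:
Compound 1 `CCN(CC)CCNC(=O)c1ccc(C(CC)(CC)c2ccc(OCS(=O)(=O)c3ccccc3)c(C)c2)n1CC`: 7130 nM
Compound 2 `CCn1c(C(=O)N[C@@H](CO)C(C)C)ccc1C(CC)(CC)c1ccc(OCS(=O)(=O)c2ccccc2)c(C)c1`: 10600 nM

In a functional assay on PC-3 cells (Homo sapiens) for antiproliferative activity, read by MTT assay, with a stated time of 24 h (on this read-out lower numbers stand for stronger inhibition and higher numbers for weaker inhibition), compound 1 gives 7130 nM. For the measured compounds named here, only one other compound has been measured, and compound 2 sits within the scatter of compound 1: a 1.5-fold higher number from compound 1 to compound 2 (0.17 log units; within the scatter).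

Compound 3 `CCn1c(C(=O)NC2(C(=O)O)CC2)ccc1C(CC)(CC)c1ccc(OCS(=O)(=O)c2ccccc2)c(C)c1` has not yet been measured. It differs from compound 1 at one place only, the amide-type nitrogen: 1-carboxycyclopropyl in place of 2-(diethylamino)ethyl on an amide-type nitrogen.

Going by the values given here, the single measured step bears on this change in a loose way. It also swapped the 2-(diethylamino)ethyl group on the same amide-type nitrogen for a group carrying a hydroxyl, and it produced a 1.5-fold higher number from compound 1 to compound 2 (0.17 log units; within the scatter). Among the compounds with values here, no step with a carboxylic acid or a three-membered ring exists among the measured compounds. On that thin basis, the expected step is a 1.3-fold higher number from compound 1 to compound 3 (0.10 log units; within the scatter), that is, no movement beyond the scatter. Compound 3 is therefore estimated at 9000 nM, with a range from 4000 nM to 25000 nM.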

Compound 3, half-maximal inhibitory concentration: 26300 nM
The estimate for compound 3 lay 2.9-fold (0.47 log units) below the measured number; the measured number lies above the stated range.
By their numbers in this assay, from the lowest: compounds 1 and 2 (each within the scatter of the next); then compound 3.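

In this assay, the group on the amide-type nitrogen now moves the number beyond the scatter: 1-carboxycyclopropyl in place of 2-(diethylamino)ethyl gives a 3.7-fold higher number from compound 1 to compound 3 (0.57 log units; beyond the scatter), and 1-carboxycyclopropyl in place of 1-(hydroxymethyl)-2-methylpropyl gives a 2.5-fold higher number from compound 2 to compound 3 (0.39 log units; beyond the scatter), both modest steps. The earlier step between compound 1 and compound 2 stayed within the scatter, so this position tolerated one exchange, while compound 3 is the weakest inhibitor of the three. No measurement here gives a reason for the shift. On these data alone, compound 3 brings the carboxylic acid and the three-membered ring in together, so their separate contributions remain open. A plain cyclopropyl group or a methyl ester on the same nitrogen would help to tell them apart.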